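From ethyl to methoxy on the shared core

The source may hold more compounds than are shown below. What is called first, only, known or untested is meant among the compounds shown, and "the series" means these compounds.

For the measured compounds named here, in a functional assay on A2780 cells (Homo sapiens) for antiproliferative activity (a lower number here means a stronger inhibitor, a higher number a weaker inhibitor), compound 1 `Cc1cccc2c1CN(C(=O)N(C)C)CC2c1cccc(O)c1` gives 2050 nM, while compound 2 `CCc1cccc2c1CN(C(=O)N(C)C)CC2c1cccc(O)c1` gives 186 nM, the lowest of the two numbers so far. The next structure, compound 3 `COc1cccc2c1CN(C(=O)N(C)C)CC2c1cccc(O)c1`, keeps the core of compound 2 but carries methoxy in place of ethyl on an aromatic carbon. Going by the values given here, one measured step bears on this change: an 11-fold lower number from compound 1 to compound 2 (1.04 log units; beyond the scatter), a large step beyond the scatter, with methyl in place of hydrogen on a saturated chain carbon bound to an aromatic carbon. So the group at this place can move the number strongly, but no measured compound carries methoxy there. The expected change is a 2.7-fold higher number from compound 2 to compound 3 (0.43 log units; beyond the scatter), a moderate rise in this assay that is estimated to be smaller than the measured step. For compound 3 the estimated value is 500 nM, with an expected range from 130 nM to 2000 nM.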

Compound 3, half-maximal inhibitory concentration: 332 nM
Compound 3: middle estimate off by 1.5-fold (0.18 log units), on the high side; the range from low to high includes it.
By their numbers in this assay, from the lowest: compounds 2 and 3 (each within the scatter of the next); then compound 1.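

In this assay, the change shows up as a 1.8-fold higher number from compound 2 to compound 3 (0.25 log units; within the scatter) and so does not separate ethyl from methoxy on this aromatic carbon. The comparison with methyl gives a 6.2-fold lower number from compound 1 to compound 3 (0.79 log units; beyond the scatter) and shows that the better number seen with ethyl does not depend on an all-carbon group, since methoxy, which brings in an oxygen and a hydrogen-bond acceptor, also stands clearly apart from methyl. No measurement shown here explains why these groups compare as they do.

From the compounds shown here alone, it remains open whether a longer chain such as propyl, or a different group such as an amine or a chlorine atom, would stay level with compound 2 and compound 3 at this place. It is also unknown whether any such group would move the number beyond theirs.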